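From propyl to tert-butyl in a cytotoxicity series

The source may report more compounds than this note shows. Statements on the series, on what has been measured and on what is new or still open speak of the compounds shown alone.

Compound 1 (`CCCCOC1OC(=O)C(Cl)=C1Cl`) gives 22300 nM
Compound 2 (`CCCOC1OC(=O)C(Cl)=C1Cl`) gives 3500 nM

Both values come from one test (an ADME assay on BEAS-2B cells (Homo sapiens) for cytotoxicity, read by MTT assay, with a stated time of 72 h; on this read-out lower numbers stand for stronger inhibition and higher numbers for weaker inhibition). Of the two, compound 2 holds the lower number (3500 nM). Going by the values given here, the only measured step (a 6.4-fold lower number from compound 1 to compound 2 (0.80 log units; beyond the scatter)) is hydrogen in place of methyl on a saturated chain carbon, three bonds along the chain from an oxygen on a saturated carbon.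

Compound 3 (`CC(C)(C)OC1OC(=O)C(Cl)=C1Cl`) has not yet been measured. It carries tert-butyl in place of propyl on an oxygen on a saturated carbon. Among the compounds with values here, the measured step bears on this change only in part, since it concerns a methyl on a chain and no tert-butyl compound has a measured value. It therefore suggests a direction more than a size. A step to a higher number is expected, probably no larger than the measured one, and it may stay within the scatter. The expected step is modest (a 2.0-fold higher number from compound 2 to compound 3 (0.30 log units; within the scatter)). For compound 3 the estimated value is 7000 nM (expected range 2500 nM to 22000 nM).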

Compound 3, half-maximal inhibitory concentration: 23100 nM
Compound 3: the middle estimate sits 3.3-fold (0.52 log units) below what was measured, outside the stated range (above it).
By their numbers in this assay, from the lowest: compound 2; then compounds 1 and 3 (each within the scatter of the next).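

In this assay, the place on an oxygen on a saturated carbon now responds to a second change, as tert-butyl in place of propyl gives a 6.6-fold higher number from compound 2 to compound 3 (0.82 log units; beyond the scatter). Tert-butyl in place of butyl, by contrast, gives a 1.0-fold higher number from compound 1 to compound 3 (0.02 log units; within the scatter), so the printed values do not separate these two groups, although one is a straight chain and the other is branched. Among the three groups shown, propyl alone stands apart, and compound 2 keeps the lowest number at 3500 nM, with its steps to both other compounds beyond the scatter.

The compounds shown leave open whether the lower number belongs to propyl alone or continues with a shorter chain such as ethyl or methyl, and what a ring such as cyclopentyl or a chain ending in an amine would give on the same oxygen. Nothing available here accounts for the difference between propyl and the other two groups.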